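This account rests on a few compounds, and the source may have more. Where it says the series, first, only, none or still open, it means among the compounds named here.

Compound 1, `CCCCCCCN(CCCCCSc1nc(CCC)c(CCC)[nH]1)C(=O)Nc1ccc(F)cc1F`, gives 60 nM in an assay on microsomes from liver with sterol O-acyltransferase 1 (Rattus norvegicus) as the target; a higher number here means a weaker inhibitor, a lower number a stronger inhibitor. Compound 2, `CCCCCCCN(CCCCCSc1nc(-c2ccc(N(C)C)cc2)c(-c2ccc(N(C)C)cc2)[nH]1)C(=O)CC1CCCCC1`, gives 50 nM in this assay, and the two numbers lie within the scatter of each other, so compound 1 cannot be set apart from compound 2 on what has been measured. Compound 3, `CCCCCCCN(CCCCCSc1nc(C(C)C)c(C(C)C)[nH]1)C(=O)Nc1ccc(F)cc1F`, differs from compound 1 by 4,5-diisopropyl-1H-imidazol-2-yl in place of 4,5-dipropyl-1H-imidazol-2-yl on a sulfur. Going by the values given here, no measured pair shows this change, so the expected step of a 1.3-fold higher number from compound 1 to compound 3 (0.12 log units; within the scatter) is small, in either direction, with nothing beyond the scatter foreseen. Compound 3 is therefore expected to give 80 nM in this assay, with a range from 30 nM to 220 nM.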

Compound 3, half-maximal inhibitory concentration: 20 nM
Beside the measured number, compound 3's estimate is 4.0-fold (0.60 log units) above it; the measured number lies below the stated range.
By their numbers in this assay, from the lowest: compound 3; then compounds 2 and 1 (each within the scatter of the next).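

With the same atoms joined differently, 4,5-diisopropyl-1H-imidazol-2-yl in place of 4,5-dipropyl-1H-imidazol-2-yl on a sulfur gives in this assay a 3.0-fold lower number from compound 1 to compound 3 (0.48 log units; beyond the scatter), so this position responds to how the chains are joined and not only to which atoms they hold. Compound 1 and compound 2 differ in more than one place and could not show this. No measurement at hand accounts for the step. Still open, on these data alone, is whether tert-butyl or cyclohexyl groups in place of the isopropyl groups would lower the number further. As far as these compounds go, whether the same change holds on the rest of compound 2 also remains open.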